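This account rests on a few compounds, and the source may have more. Where it says the series, first, only, none or still open, it means among the compounds named here.

Measured compounds:
- compound 1 `COc1cccc(-n2cc3nc(-c4cccnc4C)n(C[C@H]4CCCN(CC5CCCCC5)C4)c(=O)c3n2)c1` — 200 nM
- compound 2 `Cc1ncccc1-c1nc2cn(-c3cccc(OC(C)C)c3)nc2c(=O)n1C[C@H]1CCCN(C[C@H]2CCCO2)C1` — 11 nM
- compound 3 `COc1cccc(-n2cc3nc(-c4cccnc4C)n(C[C@H]4CCCN(Cc5ccco5)C4)c(=O)c3n2)c1` — 2.7 nM

All three numbers come from an assay on HEK293 cells for displacement of a labelled ligand from growth hormone secretagogue receptor type 1 (Homo sapiens), with a stated time of 60 min; a lower number here means a stronger inhibitor, a higher number a weaker inhibitor. Compound 3 gives the lowest number of the three: compound 2 is the nearest, and compound 1 the furthest away. Compound 3 and compound 1 share everything except the group on the saturated chain carbon bound to the amine nitrogen in the ring, and the step of a 74-fold lower number from compound 1 to compound 3 (1.87 log units; beyond the scatter) is large. Compound 2 differs from compound 3 in two places at once, so its value is only a second point of reference.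

Compound 4 `COc1cccc(-n2cc3nc(-c4cccnc4C)n(C[C@H]4CCCN(CC5CCC5)C4)c(=O)c3n2)c1` is not yet measured. It differs from compound 3 by cyclobutyl in place of furan-2-yl on a saturated chain carbon bound to an amine nitrogen in a ring. Among the compounds with values here, the one step that bears on this change is the swap of a saturated carbocycle for the furan-2-yl group, seen as a 74-fold lower number from compound 1 to compound 3 (1.87 log units; beyond the scatter). Compound 4 moves back from the furan-2-yl group toward a saturated carbocycle, though a smaller one than in compound 1. A higher number than for compound 3 is therefore expected, and a 15-fold higher number from compound 3 to compound 4 (1.17 log units; beyond the scatter) is the step estimated for compound 4, because compound 1 with its cyclohexyl gives 200 nM. For compound 4 the expected value is 40 nM, within 10 nM to 200 nM.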

Compound 4, half-maximal inhibitory concentration: 1.6 nM
Beside the measured number, compound 4's estimate is 25-fold (1.40 log units) above it, outside the stated range (below it).
By their numbers in this assay, from the lowest: compounds 4 and 3 (each within the scatter of the next); then compound 2; then compound 1.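

In this assay the furan-2-yl group proves replaceable at this position: putting cyclobutyl in its place gives a 1.7-fold lower number from compound 3 to compound 4 (0.23 log units; within the scatter) and so leaves the number within the scatter, even though a five-membered aromatic ring with one oxygen has given way to a four-membered ring of carbon only. The large earlier step therefore cannot be read as a simple contrast of aromatic ring against saturated carbocycle, for the change from cyclohexyl to cyclobutyl alone gives a 130-fold lower number from compound 1 to compound 4 (2.10 log units; beyond the scatter) and compound 1 is the one that stands apart from compound 3 and compound 4 in this set. Nothing available here explains why cyclohexyl differs so much from the other two groups.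

The compounds shown leave open how the number behaves for a ring of intermediate size such as cyclopentyl, and so whether it climbs gradually or abruptly on the way to cyclohexyl. They also leave open whether an open chain such as isobutyl, or an aromatic ring with sulfur such as thiophen-2-yl, would fit this position equally well.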